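The compounds below may be only part of what the source reports. "The series", "measured", "known", "first", "only" and "open" are said of these compounds alone.

Among the measured compounds shown here, compound 1 `Cc1ccc(-c2nnc(COc3cnn(C(C)(C)C)c(=O)c3Cl)o2)cc1` has the lowest of the two numbers known so far in a functional assay on the whole organism for inhibition, with Mythimna separata as the target, with a stated time of 5 days; on this read-out higher numbers stand for an effect only at larger amounts of compound and lower numbers for an effect already at smaller amounts. In this assay compound 1 gives 19.9 ug/mL. Compound 2 `CCCCn1ncc(OCc2nnc(-c3ccc(F)cc3)o2)c(Cl)c1=O` differs from compound 1 in several places; in this assay compound 2 gives 162 ug/mL, a gap well beyond the scatter. Compound 3 `Cc1cc(C)cc(-c2nnc(COc3cnn(C(C)(C)C)c(=O)c3Cl)o2)c1` has not yet been measured in this assay. It differs from compound 1 in one place: 3,5-dimethylphenyl in place of 4-methylphenyl on an aromatic carbon, so the change is 3,5-dimethylphenyl in place of 4-methylphenyl on an aromatic carbon. For the measured compounds named here, no step between measured compounds isolates this change, and compound 2 cannot be used for it since it differs from compound 1 in two places at once. Going by the values given here, with no direct precedent among the measured pairs, the step is expected to be small, with no clear direction beyond the scatter, so compound 3 is estimated at 25 ug/mL in this assay, within a range from 8 ug/mL to 80 ug/mL, which corresponds to an expected step of a 1.3-fold higher number from compound 1 to compound 3 (0.10 log units; within the scatter).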

Compound 3, half-maximal effective concentration: > 300 ug/mL
Compound 3 ended at the assay's limit; the forecaster's own chance of this, stated with the estimate: 10%; middle value at least 12-fold (1.07 log units) away from the limit.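

Replacing 4-methylphenyl with 3,5-dimethylphenyl on the aromatic carbon of the five-membered ring gives an at least 15-fold higher number from compound 1 to compound 3 (1.17 log units; beyond the scatter) in this assay. This is the only single-place step among the compounds shown, and it makes clear that the group on this carbon is not a place where the aryl substitution can be varied freely: a change of just one carbon in the leaving and entering groups, with the same ring and no change in the hydrogen-bond counts, is enough to take the effect out of the measurable range. For compound 3 the value > 300 ug/mL is a limit of the assay and not a number, so the size of the step is open on one side: the limit of > 300 ug/mL in this assay, at which 1 of the 3 values shown sits.

The compounds shown cannot separate the extra methyl from the altered arrangement of methyl groups on the phenyl ring, and a plain phenyl on the same carbon would be needed to begin to tell these apart. They also leave open how a methoxy group or a chlorine on that phenyl ring would fare on the core of compound 1.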